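A few compounds are considered here, and "the series" means these few. Any claim that something is new, unique, unknown or untested is made for them only; others in the source may bear on it.

Measured so far:
compound 1, `CCCC(=O)Nc1c(C(O)(C(F)(F)F)C(F)(F)F)ccc2ccccc12`, 131 nM;
compound 2, `O=C(Nc1c(C(O)(C(F)(F)F)C(F)(F)F)ccc2ccccc12)C1CC1`, 751 nM;
compound 3, `Cc1ccccc1C(=O)Nc1c(C(O)(C(F)(F)F)C(F)(F)F)ccc2ccccc12`, 5550 nM.

In an assay on LtK cells with ATP-sensitive inward rectifier potassium channel 11 (Homo sapiens) as the target (on this read-out lower numbers stand for an effect already at smaller amounts and higher numbers for an effect only at larger amounts of compound), compound 2 stands second highest of the three numbers, between compound 1, with a 5.7-fold higher number from compound 1 to compound 2 (0.76 log units; beyond the scatter), and compound 3, with a 7.4-fold higher number from compound 2 to compound 3 (0.87 log units; beyond the scatter). Compound 4, `O=C(Nc1c(C(O)(C(F)(F)F)C(F)(F)F)ccc2ccccc12)c1cccc(Br)c1`, differs from compound 2 in one place: 3-bromophenyl in place of cyclopropyl on a carbonyl carbon. Going by the values given here, of the measured steps, only the one from compound 2 to compound 3 swaps the cyclopropyl for an aromatic ring, and it gave a 7.4-fold higher number from compound 2 to compound 3 (0.87 log units; beyond the scatter); the wider move from propyl to an aromatic ring gave a 42-fold higher number from compound 1 to compound 3 (1.63 log units; beyond the scatter). On that basis a modest rise in the number is expected, a 4.0-fold higher number from compound 2 to compound 4 (0.60 log units; beyond the scatter), and compound 4 is estimated at 3000 nM, between 1000 nM and 10000 nM.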

Compound 4, half-maximal effective concentration: 80 nM
Estimate against measurement, compound 4: 38-fold (1.57 log units) above, and the stated range ends above it.
By their numbers in this assay, from the lowest: compounds 4 and 1 (each within the scatter of the next); then compound 2; then compound 3.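

In this assay the step of a 9.4-fold lower number from compound 2 to compound 4 (0.97 log units; beyond the scatter) and the step of a 69-fold lower number from compound 3 to compound 4 (1.84 log units; beyond the scatter) show that an aromatic ring on this carbonyl carbon carries no penalty in itself, and that the choice of ring sets the number. The step of a 1.6-fold lower number from compound 1 to compound 4 (0.21 log units; within the scatter) puts the 3-bromophenyl group level with the propyl chain. Nothing measured here gives a reason for these shifts.

Still open, going by these compounds, is whether the bromine matters at all, which an unsubstituted phenyl group or a ring carrying chlorine in its place would test.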